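Swapping a hydroxylated side chain for a branched alkyl

The compounds below may be only part of what the source reports. "The series", "measured", "known", "first", "only" and "open" are said of these compounds alone.

Compound 3, `CC(C)(CO)/N=c1\c(O)c(O)\c1=N/Cc1ccc(C#N)cc1`, gives 21300 nM in a functional assay for inhibition, with Rattus norvegicus as the target (on this read-out higher numbers stand for weaker inhibition and lower numbers for stronger inhibition), the highest of the three numbers measured; compound 1, `CC(/N=c1\c(O)c(O)\c1=N/[C@H](C)C(C)(C)C)c1ccc(C#N)cc1`, sits nearest with 6500 nM, and compound 2, `CC[C@H](C)/N=c1\c(O)c(O)\c1=N/Cc1ccc(C#N)cc1`, furthest with 2200 nM. The step from compound 3 to compound 4, `C[C@@H](/N=c1\c(O)c(O)\c1=N/Cc1ccc(C#N)cc1)C(C)(C)C`, is 1,2,2-trimethylpropyl in place of 1-(hydroxymethyl)-1-methylethyl on a double-bonded nitrogen. Going by the values given here, the one measured step that bears on it runs the other way: a 9.7-fold higher number from compound 2 to compound 3 (0.99 log units; beyond the scatter), where a plain alkyl group gave way to the hydroxylated chain and the number rose clearly. Among the compounds with values here, compound 4 returns to a plain alkyl, the same 1,2,2-trimethylpropyl that compound 1 carries on its other double-bonded nitrogen while compound 1 also bears a methyl on its benzylic carbon; compound 1 and compound 4 have no measured step between them. Compound 4 is therefore expected to show a step of an 8.5-fold lower number from compound 3 to compound 4 (0.93 log units; beyond the scatter) in this assay, toward a lower number. The estimate for compound 4 is 2500 nM, with a range from 800 nM to 8000 nM.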

Compound 4, half-maximal inhibitory concentration: 270 nM
For compound 4 the middle estimate is 9.3-fold (0.97 log units) above the measured one; measured number below the stated range.
By their numbers in this assay, from the lowest: compound 4; then compound 2; then compound 1; then compound 3.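

On the double-bonded nitrogen, 1,2,2-trimethylpropyl in place of 1-(hydroxymethyl)-1-methylethyl gives a 79-fold lower number from compound 3 to compound 4 (1.90 log units; beyond the scatter) in this assay, and the same group in place of sec-butyl gives an 8.1-fold lower number from compound 2 to compound 4 (0.91 log units; beyond the scatter), so the plain alkyl groups at this position are not equivalent and the larger of the two gives the lower number. The methyl on the saturated chain carbon bound to an aromatic carbon and a double-bonded nitrogen also counts, since hydrogen in its place gives a 24-fold lower number from compound 1 to compound 4 (1.38 log units; beyond the scatter) in this assay. Nothing available accounts for the size of these steps.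

The compounds shown leave open how a cyclohexyl group or a longer alkyl chain would fare on this nitrogen. They also leave open how tert-butyl, the carbon-only counterpart of the hydroxylated chain, would compare, and whether the opposite stereocentre in 1,2,2-trimethylpropyl would give the same number.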